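Swapping a carboxy group for hydrogen in a cytotoxicity test

The source may hold more compounds than are shown below. What is called first, only, known or untested is meant among the compounds shown, and "the series" means these compounds.

The measure of cell toxicity here is an ADME assay on HepG2 cells (Homo sapiens) for cytotoxicity, with a stated time of 72 h; on this read-out lower numbers stand for an effect already at smaller amounts and higher numbers for an effect only at larger amounts of compound. Compound 1 (`O=C(O)COc1cc(Cl)c(C(=O)Nc2cccc(-c3nc4ccccc4s3)c2)cc1[N+](=O)[O-]`) gives > 25000 nM as its result, and this is a limit of the assay, not a number. Compound 2 (`COc1ccc(-c2nc3ccccc3o2)cc1NC(=O)c1cc([N+](=O)[O-])ccc1Cl`) gives > 25000 nM as its result, also a limit. Compound 3 (`O=C(Nc1ccc(-c2nc3ccccc3s2)cc1)c1cc([N+](=O)[O-])ccc1Cl`) gives > 27000 nM as its result, again a limit. Compound 1 therefore stands with no exact number, at the limit of > 25000 nM in this assay, at which 2 of the 3 values shown sit, while the remaining value lies at the limit of > 27000 nM in this assay, at which 1 of the 3 values shown sits.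

Compound 4 (`COc1cc(Cl)c(C(=O)Nc2cccc(-c3nc4ccccc4s3)c2)cc1[N+](=O)[O-]`) has not yet been measured. Its structure departs from compound 1 by hydrogen in place of carboxy on a saturated chain carbon bound to an oxygen on an aromatic ring, which is hydrogen in place of carboxy on a saturated chain carbon bound to an oxygen on an aromatic ring, so carboxymethoxy becomes methoxy.

Among the measured compounds shown here, no measured pair isolates this change. Compound 2 has no carboxy either and still shows the limit > 25000 nM in this assay. No change beyond the usual scatter is therefore expected, in either direction, and the estimated step (a number no higher from compound 1 to compound 4 (the limit leaves the size open)) should be read that way. Compound 4 is estimated at 25000 nM as its value, with an expected range of 10000 nM to 50000 nM around it.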

Compound 4, half-maximal effective concentration: > 25000 nM
Compound 4: a limit, no number (the forecaster's own chance of this, stated with the estimate: 70%); the middle value lies on the limit itself.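

In this assay, compound 1 and compound 4 both end at a limit of the assay rather than a number, so the step between them cannot be read. The compounds shown leave open whether hydrogen in place of carboxy changes the cytotoxicity read-out at all.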